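A few compounds are considered here, and "the series" means these few. Any claim that something is new, unique, unknown or untested is made for them only; others in the source may bear on it.

Compound 1 `Cc1nnsc1CO/N=C/c1c(C)nn(C)c1Oc1ccc(F)cc1` is the starting point. In a functional assay on Huh-7 cells (Homo sapiens) for inhibition, read by MTT assay, with a stated time of 48 h (a lower number here means a stronger inhibitor, a higher number a weaker inhibitor), compound 1 gives > 50000 nM, which is a limit of the assay rather than a number. Compound 2 `Cc1nnsc1CO/N=C/c1c(C)nn(C)c1Oc1cc(F)cc(F)c1` differs from compound 1 by carrying 3,5-difluorophenyl in place of 4-fluorophenyl on an oxygen on an aromatic ring. In this assay compound 2 gives > 50000 nM, likewise a limit. The step that the two limits leave unreadable from compound 1 to compound 2 therefore cannot be read, and the limit of > 50000 nM in this assay, at which 2 of the 2 values shown sit, is all that the two measurements say about where compound 1 stands. Compound 3 `Cc1nnsc1CO/N=C/c1c(C)nn(C)c1Cl` has not yet been measured. It differs from compound 1 by chloro in place of 4-fluorophenoxy on an aromatic carbon. Within the data shown here, no measured step covers this change, and neither measured compound gives a number from which a direction could be taken. Compound 3 is therefore expected to sit near the same limit, an expected step of a number no higher from compound 1 to compound 3 (the limit leaves the size open). The estimate for compound 3 in this assay is 50000 nM, expected to lie between 15000 nM and 150000 nM.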

Compound 3, half-maximal inhibitory concentration: > 50000 nM
Compound 3 was reported as a limit; the forecaster's own chance of this, stated with the estimate: 80%; the middle value lies on the limit itself.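

Compound 3 is reported only as a limit in this assay, as are compound 1 and compound 2, so the step from compound 1 to it cannot be read: the limit of > 50000 nM in this assay, at which 3 of the 3 values shown sit.

The compounds shown leave open how far apart the three truly lie, and which change to the shared core, if any, would give a readable number.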